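From cyclobutyl to ethynyl: an expected cytotoxicity step

This account rests on a few compounds, and the source may have more. Where it says the series, first, only, none or still open, it means among the compounds named here.

Three macrocycles built on one shared core have been examined in an ADME assay on Huh-7 cells (Homo sapiens) for cytotoxicity, read by colorimetric assay; a higher number here means that more compound is tolerated, a lower number that less compound is tolerated. Compound 1 `COc1cc2c(O[C@H]3C[C@H]4C(=O)N(C)CCCC/C=C/[C@@H]5C[C@@]5(C(=O)NS(=O)(=O)C5(C)CC5)NC(=O)N4C3)cc(-c3nc(C(C)C)cs3)nc2cc1Cl` gave only a limit in this assay, > 75000 nM. Compound 2 `COc1ccc2c(O[C@H]3C[C@H]4C(=O)N(C)CCCC/C=C/[C@@H]5C[C@@]5(C(=O)NS(=O)(=O)C5CC5)NC(=O)N4C3)cc(-c3nc(C4CC4)cs3)nc2c1Cl` gave 31300 nM in this assay. Compound 3 `COc1ccc2c(O[C@H]3C[C@H]4C(=O)N(C)CCCC/C=C/[C@@H]5C[C@@]5(C(=O)NS(=O)(=O)C5(C)CC5)NC(=O)N4C3)cc(-c3nc(C4CCC4)cs3)nc2c1Cl` gave 75000 nM in this assay, the highest of the two numbers, and its nearest neighbour among the numbers is compound 2, a gap that lies beyond the scatter. The third value is the limit of > 75000 nM in this assay, at which 1 of the 3 values shown sits, which belongs to compound 1 alone.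

Compound 4 `C#Cc1csc(-c2cc(O[C@H]3C[C@H]4C(=O)N(C)CCCC/C=C/[C@@H]5C[C@@]5(C(=O)NS(=O)(=O)C5(C)CC5)NC(=O)N4C3)c3ccc(OC)c(Cl)c3n2)n1` has not yet been measured in this assay. It differs from compound 3 in a single place: ethynyl in place of cyclobutyl on an aromatic carbon, in words ethynyl in place of cyclobutyl on an aromatic carbon. Among the compounds with values here, no pair of measured compounds shares this exchange, so no measured step gives its direction or size. With compound 3 already at a high number, the expectation is that this change produces no step beyond the scatter in this assay, with a modest chance that the reading again comes back as a limit. The step from compound 3 to compound 4 is therefore expected to be a 1.3-fold lower number from compound 3 to compound 4 (0.10 log units; within the scatter). For compound 4 in this assay the estimate is 60000 nM, with a range from 25000 nM to 150000 nM.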

Compound 4, half-maximal cytotoxic concentration: 17000 nM
Beside the measured number, compound 4's estimate is 3.5-fold (0.55 log units) above it, and the stated range ends above it.
By their numbers in this assay, from the lowest: compounds 4 and 2 (each within the scatter of the next); then compound 3.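

Within the data shown here, compound 4 supplies the first single-place comparison: in this assay, exchanging cyclobutyl for ethynyl on the aromatic carbon next to the ring nitrogen brings a 4.4-fold lower number from compound 3 to compound 4 (0.64 log units; beyond the scatter). The group at this position is therefore not indifferent in this assay, since this one exchange, with the rest of the structure unchanged, moves the amount of compound tolerated by more than the usual scatter. The exchange removes the four-membered carbon ring, lowers the heavy-atom count and adds a triple bond outside the aromatic rings, and nothing shown here says which of these differences, if any, accounts for the step.

One exchange gives a single step at a single position, so it cannot separate the loss of the ring from the arrival of the triple bond. As far as these compounds go, how an ethyl group, which has no ring and no triple bond, or a nitrile at this same carbon would read in this assay stays open, as does whether the same exchange would give a step of this size on the other macrocycles.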